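Methoxy to Hydroxy at the Edge of Detection

The compounds below may be only part of what the source reports. "The series", "measured", "known", "first", "only" and "open" are said of these compounds alone.

In a functional assay on CAKI-1 cells (Homo sapiens) for inhibition, read by sulforhodamine B assay, with a stated time of 48 h (on this read-out higher numbers stand for lower toxicity in this test and lower numbers for higher toxicity in this test), compound 1 `COc1cc(C)cc(-c2nn(CC#N)cc2-c2ccc(-c3cccc(C(C)=O)c3)nc2)c1` reaches only a limit of the test, > 100000 nM. Compound 2 `Cc1cc(O)cc(-c2nn(CC#N)cc2-c2ccnc(-c3ccc(Oc4ccccc4)cc3)c2)c1` gives 41000 nM in this assay. Compound 3 `COc1cc(C)cc(-c2nn(CC#N)cc2-c2ccnc(-c3ccc(N(C)C)cc3)c2)c1` likewise reaches only a limit in this assay, > 100000 nM. Compound 3 thus stands at the limit of > 100000 nM in this assay, at which 2 of the 3 values shown sit; no number is known for it, and nothing beyond the limit can be read from it. Compound 4 `Cc1cc(O)cc(-c2nn(CC#N)cc2-c2ccnc(-c3ccc(N(C)C)cc3)c2)c1` has not been measured; it differs from compound 3 by hydrogen in place of methyl on an oxygen on an aromatic ring. Among the measured compounds shown here, no pair of measured compounds shows this change on its own, so the size of the step is open. With compound 3 at a limit, compound 4 is expected to stay near that limit, a step of a number no higher from compound 3 to compound 4 (the limit leaves the size open) within the scatter. Compound 4 is estimated at 100000 nM, between 40000 nM and 250000 nM.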

Compound 4, concentration lethal to 50% of the cells: > 100000 nM
Compound 4: a limit, no number; the forecaster's own chance of this, stated with the estimate: 60%; the middle value lies on the limit itself.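

Compound 3 and compound 4 both stop at a limit of the test, so the change from methoxy to hydroxy cannot be read. Compound 4 does add one readable comparison in this assay: with hydroxy kept, dimethylamino in place of phenoxy gives an at least 2.4-fold higher number from compound 2 to compound 4 (0.38 log units; beyond the scatter). Most of the set now rests at that same limit: the limit of > 100000 nM in this assay, at which 3 of the 4 values shown sit.

On these data alone, whether methoxy and hydroxy differ at all in this test stays open. So does what an amine or a carboxylic acid would give in their place.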